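From 2-methylphenyl to 4-chlorophenyl on the sulfonyl sulfur

The source may hold more compounds than are shown below. What is called first, only, known or untested is meant among the compounds shown, and "the series" means these compounds.

In a functional assay on MDA-MB-231 cells (Homo sapiens) for inhibition, read by sulforhodamine B assay, with a stated time of 74 h (on this read-out lower numbers stand for stronger inhibition and higher numbers for weaker inhibition), compound 1 (`Cc1ccc(S(=O)(=O)N2C(=O)COC23C=CC(=O)C=C3)cc1`) gives 70 nM. Compound 2 (`CS(=O)(=O)N1C(=O)COC12C=CC(=O)C=C2`) reads > 10000 nM, which is a limit of the assay and not a number. Compound 3 (`Cc1ccccc1S(=O)(=O)N1C(=O)COC12C=CC(=O)C=C2`) reads > 10000 nM, again only a limit, so its position on the scale is open.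

The next compound is compound 4 (`O=C1C=CC2(C=C1)OCC(=O)N2S(=O)(=O)c1ccc(Cl)cc1`), with 4-chlorophenyl in place of 2-methylphenyl on a sulfonyl sulfur. The closest measured evidence is an at least 140-fold higher number from compound 1 to compound 3 (2.15 log units; beyond the scatter), a large change beyond the scatter that involves the same place. A second large change beyond the scatter, an at least 140-fold higher number from compound 1 to compound 2 (2.15 log units; beyond the scatter), shows that this place can also lose the activity of compound 1 in another way.

Of the measured compounds, only compound 1 at 70 nM carries a 4-methylphenyl group, the nearest match to 4-chlorophenyl, although this rests on a single example. A large move towards a lower number is therefore expected, estimated as an at least 83-fold lower number from compound 3 to compound 4 (1.92 log units; beyond the scatter). For compound 4 the estimated value is 120 nM, with an expected range of 25 nM to 800 nM.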

Compound 4, half-maximal inhibitory concentration: 2800 nM
Compound 4: the middle estimate sits 23-fold (1.37 log units) below what was measured, and the stated range ends below it.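

In this assay a second substituted phenyl group on the sulfonyl sulfur gives a number that can be read, an at least 3.5-fold lower number from compound 3 to compound 4 (0.55 log units; beyond the scatter) and an at least 3.5-fold lower number from compound 2 to compound 4 (0.55 log units; beyond the scatter). Both steps are only minimum sizes because each starts from a value that is a limit of the assay and not a number: the limit of > 10000 nM in this assay, at which 2 of the 4 values shown sit. The exchange on the aromatic ring is far from neutral, with a 40-fold higher number from compound 1 to compound 4 (1.60 log units; beyond the scatter), so 4-methylphenyl and 4-chlorophenyl cannot be treated as interchangeable in this series, and compound 1 keeps the lowest number of the four.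

As far as these compounds go, with only methyl and chloro compared on that ring, the reading for a 4-methoxyphenyl or 4-aminophenyl group on the sulfonyl sulfur stays open. A 2-chlorophenyl group would show whether the limit reading of compound 3 carries over from 2-methylphenyl to another group.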